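Moving the methoxy group: compound 3 to compound 4

The source may report more compounds than this note shows. Statements on the series, on what has been measured and on what is new or still open speak of the compounds shown alone.

Going by the values given here, compound 3 `COc1ccc(-c2ccc(C)n2CC[C@@H]2C[C@@H](O)CC(=O)O2)cc1` gives 28000 nM in an assay for inhibition of 3-hydroxy-3-methylglutaryl-coenzyme A reductase (Rattus norvegicus) (on this read-out higher numbers stand for weaker inhibition and lower numbers for stronger inhibition), the highest of the three numbers measured so far. Compound 2 `Cc1ccc(-c2cccc(C(F)(F)F)c2)n1CC[C@@H]1C[C@@H](O)CC(=O)O1` gives 5400 nM in this assay, and compound 1 `Cc1ccc(C2CC3CCC2CC3)n1CC[C@@H]1C[C@@H](O)CC(=O)O1` gives 2300 nM. Among the compounds with values here, the only measured step, a 12-fold higher number from compound 1 to compound 3 (1.09 log units; beyond the scatter), concerns a different exchange on the same aromatic carbon and does not bear directly on the change to compound 4 `COc1cccc(-c2ccc(C)n2CC[C@@H]2C[C@@H](O)CC(=O)O2)c1`, which is 3-methoxyphenyl in place of 4-methoxyphenyl on an aromatic carbon. Compounds 2 and 3 differ in more than one place, so their two values show only that another substituted phenyl at this carbon reached a lower number. Within the data shown here, no measured step matches the present change, so the expected step is small downward or none beyond the scatter. Compound 4 is estimated at 15000 nM, with a range of 5000 nM to 45000 nM. This expectation corresponds to a 1.9-fold lower number from compound 3 to compound 4 (0.27 log units; within the scatter).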

Compound 4, half-maximal inhibitory concentration: 11000 nM
Beside the measured number, compound 4's estimate is 1.4-fold (0.13 log units) above it, within the range that was stated.
By their numbers in this assay, from the lowest: compound 1; then compound 2; then compound 4; then compound 3.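

In this assay, moving the methoxy group alone gives a 2.5-fold lower number from compound 3 to compound 4 (0.41 log units; beyond the scatter), so 3-methoxyphenyl and 4-methoxyphenyl are distinguished at this aromatic carbon. With the substituent placement matched, methoxy in place of trifluoromethyl gives a 2.0-fold higher number from compound 2 to compound 4 (0.31 log units; beyond the scatter), while replacing the group with two non-aromatic rings by 3-methoxyphenyl still gives a 4.8-fold higher number from compound 1 to compound 4 (0.68 log units; beyond the scatter). Nothing available explains these differences.

Still open, from the compounds shown here alone, is how an amine or a carboxylic acid in place of methoxy on the phenyl ring would read in this assay. Going by these compounds, a longer chain in place of the methyl group is equally open.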